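A second swap of the aryl group on a nitro-pyrimidine

This account rests on a few compounds, and the source may have more. Where it says the series, first, only, none or still open, it means among the compounds named here.

Of the compounds shown here, three built on a nitro-substituted pyrimidine core have been tested for their ability to slow the growth of liver cancer cells. Compound 1 `COC(=O)CN(C)c1nc(Nc2ccc(Cl)cc2)ncc1[N+](=O)[O-]` gives 49800 nM in a functional assay on HepG2 cells (Homo sapiens) for antiproliferative activity, read by MTT assay, with a stated time of 48 h; a lower number here means a stronger inhibitor, a higher number a weaker inhibitor. Compound 2 `COC(=O)CN(C)c1nc(Nc2cccc(OC)c2)ncc1[N+](=O)[O-]` gives 73400 nM in this assay. The only difference between them is 3-methoxyphenyl in place of 4-chlorophenyl on a nitrogen on an aromatic ring, and this change gives a 1.5-fold higher number from compound 1 to compound 2 (0.17 log units; within the scatter).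

Compound 3 `CCOC(=O)CN(Cc1ccccc1)c1nc(Nc2ccc(Cl)cc2)ncc1[N+](=O)[O-]` carries a different core from compound 1, and how the two cores differ is not broken down here. In this assay compound 3 gives 30900 nM, the lowest of the three numbers, but its gap to compound 1 is within the scatter, while its gap to compound 2 is beyond it.

Compound 4 `CCOC(=O)CN(Cc1ccccc1)c1nc(Nc2cccc(OC)c2)ncc1[N+](=O)[O-]` has not been measured. It differs from compound 3 by 3-methoxyphenyl in place of 4-chlorophenyl on a nitrogen on an aromatic ring. For the measured compounds named here, this is the same change as the one from compound 1 to compound 2, made on the same kind of nitrogen with the same surroundings, so that earlier step is the best guide to what it will do here.

Because the step of a 1.5-fold higher number from compound 1 to compound 2 (0.17 log units; within the scatter) was small and within the scatter, the number for compound 4 is expected to move only modestly, by a 1.5-fold higher number from compound 3 to compound 4 (0.17 log units; within the scatter). On this basis compound 4 is estimated to give 46000 nM in this assay, most likely falling between 24000 nM and 90000 nM.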

Compound 4, half-maximal inhibitory concentration: 27600 nM
The estimate for compound 4 lay 1.7-fold (0.22 log units) above the measured number, and the stated range covers the measured number.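

In this assay, putting 3-methoxyphenyl in place of 4-chlorophenyl on the core of compound 3 gives a 1.1-fold lower number from compound 3 to compound 4 (0.05 log units; within the scatter) and so leaves the number within the scatter, as it did on the core of compound 1. The two results agree as closely as this kind of measurement can tell: the same change on two cores in this assay, a 1.5-fold higher number (0.17 log units; within the scatter) from compound 1 to compound 2 and a 1.1-fold lower number (0.05 log units; within the scatter) from compound 3 to compound 4, 1.7-fold (0.22 log units) apart, within the scatter of two such steps. This shows that, for these two pairs, the choice of either aryl group on that nitrogen made no clear difference on either core, and that the step on one core was a fair guide to the step on the other, but two small steps do not prove that the swap would behave the same way on every core in the series, nor do they show how a change with a large effect would carry over.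

The compounds shown leave open whether a group of a different kind on the phenyl ring, such as a nitrile or a trifluoromethyl group, would shift the number beyond the scatter. They also leave open what a carboxylic acid or an amide in place of the ester would do on either core.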